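The source may report more compounds than this note shows. Statements on the series, on what has been measured and on what is new or still open speak of the compounds shown alone.

Two compounds of this series have numbers in an assay on cells for inhibition of histone deacetylase 8 (Homo sapiens), read by fluorescence, with a stated time of 60 min; a lower number here means a stronger inhibitor, a higher number a weaker inhibitor. Compound 1 `COc1ccc(Oc2ccc3nc(/C=C/C(=O)NO)ccc3c2)cc1` gives 7750 nM in this assay and stands highest of the two. Compound 2 `COc1cc(Oc2ccc3nc(/C=C/C(=O)NO)ccc3c2)cc(OC)c1OC` gives 2820 nM in this assay; its number is lower than that of compound 1, and the gap is beyond the scatter. Compound 3 `O=C(/C=C/c1ccc2cc(Oc3ccc([N+](=O)[O-])cc3)ccc2n1)NO` has not yet been measured in this assay. It differs from compound 1 in one place: nitro in place of methoxy on an aromatic carbon, para to a large group. Among the compounds with values here, no measured pair shows this change, so its effect cannot be read from the two numbers at hand. A small step toward a lower number is expected, one that may stay within the scatter of this assay, so the step of a 1.6-fold lower number from compound 1 to compound 3 (0.19 log units; within the scatter) is estimated to be modest. For compound 3 the expected value in this assay is 5000 nM, with a range from 1500 nM to 16000 nM.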

Compound 3, half-maximal inhibitory concentration: 2320 nM
Estimate against measurement, compound 3: 2.2-fold (0.33 log units) above, within the range that was stated.
By their numbers in this assay, from the lowest: compounds 3 and 2 (each within the scatter of the next); then compound 1.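

In this assay, within the data shown here, the change from methoxy to nitro on an aromatic carbon, para to a large group, gives a 3.3-fold lower number from compound 1 to compound 3 (0.52 log units; beyond the scatter), the first step that can be read for a single change. This position therefore responds to its substituent, and the methoxy of compound 1 is not needed to hold the number, since nitro takes its place and the number falls. Nothing at hand accounts for this step.

Whether the step belongs to nitro alone stays open, since the compounds shown include no amine, carboxylic acid, halogen or unsubstituted ring at this place. One pair also cannot show whether the same change would give a similar step on the aromatic ring of compound 2, which carries more methoxy groups.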